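Tertiary alcohol in place of the primary one

The source may hold more compounds than are shown below. What is called first, only, known or untested is meant among the compounds shown, and "the series" means these compounds.

Two compounds share one core. Compound 1 `CCCCNC(=O)c1cnc(Nc2ccc3ncsc3c2)cc1NC(C)C` gives 55% in an ADME assay on microsomes from liver (Homo sapiens) for metabolic stability (a lower number here means that less of the compound is left, a higher number that more of the compound is left), and compound 2 `CC(C)Nc1cc(Nc2ccc3ncsc3c2)ncc1C(=O)NCCCO` gives 84%, the higher of the two numbers shown, after the step of a number 29 percentage points higher from compound 1 to compound 2 (beyond the scatter). Compound 3 `CC(C)Nc1cc(Nc2ccc3ncsc3c2)ncc1C(=O)NCCC(C)(C)O` is not yet measured; it differs from compound 2 by 1-hydroxy-1-methylethyl in place of hydroxymethyl on a saturated chain carbon, two bonds along the chain from an amide-type nitrogen. Within the data shown here, the only measured step, from compound 1 to compound 2, exchanged a methyl for a hydroxy at the chain end, whereas the change to compound 3 keeps the hydroxy and adds two methyl groups beside it on the same carbon; no measured pair shows this kind of change, so it gives no direct guide. The estimate for compound 3 therefore stays near compound 2, with a slightly lower middle and a wide range: 76% (55% to 92%), a step of a number 8 percentage points lower from compound 2 to compound 3 (within the scatter), which is expected to lie within the scatter.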

Compound 3, percent of the compound remaining: 79%
The estimate for compound 3 lay 3 percentage points below the measured number; the range from low to high includes it.
By their numbers in this assay, from the lowest: compound 1; then compounds 3 and 2 (each within the scatter of the next).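

Placing the tertiary alcohol on this chain gives a number 5 percentage points lower from compound 2 to compound 3 (within the scatter) in this assay, so at this position, on a saturated chain carbon, two bonds along the chain from an amide-type nitrogen, 1-hydroxy-1-methylethyl and hydroxymethyl cannot be told apart in this read-out. Against the chain without a hydroxy, 1-hydroxy-1-methylethyl in place of ethyl gives a number 24 percentage points higher from compound 1 to compound 3 (beyond the scatter) and so, like compound 2, compound 3 stands clearly above compound 1. Nothing available explains why these numbers fall as they do.

Going by these compounds, it remains open how an amine or a carboxylic acid at the chain end would read in this assay in place of the hydroxy. The compounds shown also leave open whether a longer chain carrying the same tertiary alcohol would hold the number seen for compound 3.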